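A few compounds are considered here, and "the series" means these few. Any claim that something is new, unique, unknown or untested is made for them only; others in the source may bear on it.

Measured so far in a functional assay on HOS-TE85 cells (Homo sapiens) for inhibition, read by CCK-8 assay, with a stated time of 72 h; on this read-out lower numbers stand for stronger inhibition and higher numbers for weaker inhibition 
- compound 1 `COc1cc(F)ccc1N1C(=O)CSC1c1cccc(C(=O)NCCCCc2ccccc2)c1` gives 71.1 nM 
- compound 2 `COc1ccc(N2C(=O)CSC2c2cccc(C(=O)NCCCCc3ccccc3)c2)c(OC)c1` gives 90.4 nM 

Among the compounds with values here, compound 2 at 90.4 nM sits within the scatter of compound 1, and the pair is the only comparison available (a 1.3-fold higher number from compound 1 to compound 2 (0.10 log units; within the scatter)).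

Next is compound 3 `O=C(NCCCCc1ccccc1)c1cccc(C2SCC(=O)N2c2nccs2)c1` with 1,3-thiazol-2-yl in place of 2,4-dimethoxyphenyl on an amide-type nitrogen in a ring. Within the data shown here, the one measured step that bears on this (a 1.3-fold higher number from compound 1 to compound 2 (0.10 log units; within the scatter)) only puts methoxy in place of fluoro on an aromatic carbon, and it stays within the scatter. Among the measured compounds shown here, no measured pair replaces the whole aromatic group or brings in a ring with hetero atoms, so that step sets no size for the present change. In this assay a moderate increase in the number is expected, but this direction is a judgement and not a measured trend. The expected step is a 1.7-fold higher number from compound 2 to compound 3 (0.22 log units; within the scatter) as a rough estimate. For compound 3 the estimated value is 150 nM with an expected range from 40 nM to 550 nM on measurement.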

Compound 3, half-maximal inhibitory concentration: > 1000 nM
Compound 3: a limit, no number; the forecaster's own chance of this, stated with the estimate: 3%; middle value at least 6.6-fold (0.82 log units) away from the limit.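

In this assay, within the data shown here, compound 3 gives > 1000 nM, which is a limit of the assay and not a number, so the steps to it have a lower bound but no fixed size: the limit of > 1000 nM in this assay, at which 1 of the 3 values shown sits. Replacing the aryl group on the amide-type nitrogen in a ring gives an at least 11-fold higher number from compound 2 to compound 3 (1.04 log units; beyond the scatter) and an at least 14-fold higher number from compound 1 to compound 3 (1.14 log units; beyond the scatter), the first steps that lie beyond the scatter. The earlier exchange of fluoro for methoxy on the aryl group gave only a 1.3-fold higher number from compound 1 to compound 2 (0.10 log units; within the scatter), so among these three compounds this position shows a clear loss only when the whole 2,4-dimethoxyphenyl or 4-fluoro-2-methoxyphenyl group gives way to 1,3-thiazol-2-yl.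

This single change removes both aryl substituents and replaces a six-membered aromatic ring of carbon only with a five-membered aromatic ring with 2 hetero atoms, so the compounds shown cannot separate these features. Unsubstituted phenyl, pyridin-2-yl and 4-methoxythiazol-2-yl at the same position would each bear on that question, and the data leave open whether any of them would stay close to compound 1 and compound 2.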